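A Single Fluoro Swap on Compound 2

The compounds below may be only part of what the source reports. "The series", "measured", "known", "first", "only" and "open" are said of these compounds alone.

In a physicochemical assay for solubility, measured as thermodynamic solubility, with a stated time of 24 h (a higher number here means a more soluble compound, a lower number a less soluble compound), compound 1 `Cc1cc(Nc2ncc(F)c(-c3cnc(C)n3C(C)C)n2)ccc1C(=O)N(C)C` gives > 2600000 nM, which is a limit and not a number.

Compound 2 `Cc1ncc(-c2ccnc(Nc3ccc(C(N)=O)c(F)c3)n2)n1C(C)C` gives 33000 nM and compound 3 `CNC(=O)c1ccc(Nc2nccc(-c3cnc(C)n3CC3CC3)n2)cc1` gives 27000 nM, so these two stand level, within the usual scatter of each other.

Compound 4 `Cc1ncc(-c2nc(Nc3ccc(C(N)=O)c(F)c3)ncc2F)n1C(C)C` is still unmeasured and differs from compound 2 in one place: fluoro in place of hydrogen on an aromatic carbon. This is fluoro in place of hydrogen on an aromatic carbon, ortho to a 1-isopropyl-2-methyl-1H-imidazol-5-yl group.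

Going by the values given here, no measured pair shows this swap alone, so no change beyond the scatter is expected, an estimated 1.2-fold lower number from compound 2 to compound 4 (0.09 log units; within the scatter).

In this assay the expected value for compound 4 is 27000 nM, with an estimated range from 9000 nM to 80000 nM.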

Compound 4, solubility: 6000 nM
Estimate against measurement, compound 4: 4.5-fold (0.65 log units) above, outside the stated range (below it).
By their numbers in this assay, from the lowest: compound 4; then compounds 3 and 2 (each within the scatter of the next). At a limit, above all of these: compound 1.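

In this assay, fluoro in place of hydrogen on an aromatic carbon, ortho to a 1-isopropyl-2-methyl-1H-imidazol-5-yl group, brings a 5.5-fold lower number from compound 2 to compound 4 (0.74 log units; beyond the scatter). Going by these compounds alone, this is the first single change that can be read here, and it shows that one fluorine atom at this position is enough to move the number beyond the scatter. Nothing shown here accounts for this drop.

From the compounds shown here alone, this is one pair on one core, so it remains open whether the same swap would act alike on the other compounds. A chloro, a methyl or an amine on this carbon would show whether the drop is specific to fluoro.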